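This account rests on a few compounds, and the source may have more. Where it says the series, first, only, none or still open, it means among the compounds named here.

In an ADME assay on HepG2 cells (Homo sapiens) for cytotoxicity, read by MTT assay, with a stated time of 48 h (on this read-out lower numbers stand for stronger inhibition and higher numbers for weaker inhibition), compound 1 `O=S(=O)(c1cccc(-c2ccc3ncnc(Nc4ccc(OCc5cccc(F)c5)c(Cl)c4)c3c2)c1)N1CCCCC1` gives > 15000 nM, which is a limit of the assay and not a number. Compound 2 `O=S(=O)(c1ccc(-c2ccc3ncnc(Nc4ccc(OCc5cccc(F)c5)c(Cl)c4)c3c2)cc1)N1CCCC1` also reaches only a limit, > 15000 nM. So compound 1 stands at the only level seen so far: the limit of > 15000 nM in this assay, at which 2 of the 2 values shown sit. Among the measured compounds shown here, neither result is an exact value, and no measured pair shows what a single structural change does here.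

Compound 3 `Fc1cccc(COc2ccc(Nc3ncnc4ccc(-c5cccc(N6CCCCC6)c5)cc34)cc2Cl)c1` keeps the core of compound 1 and carries piperidin-1-yl in place of (piperidin-1-yl)sulfonyl on an aromatic carbon. For the measured compounds named here, with no measured step as a guide, the change expected in this assay is none beyond the scatter, and the estimated step is a step that the limit leaves unreadable from compound 1 to compound 3. That expectation rests on compound 1, whose result of > 15000 nM is a limit. Compound 3 may well end at a limit too, so the number given here is only a rough expectation. For compound 3 the estimated value is 20000 nM, with an expected range from 6000 nM to 60000 nM.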

Compound 3, half-maximal inhibitory concentration: > 15000 nM
Compound 3 gave a limit, no number; the forecaster's own chance of this, stated with the estimate: 55%; the middle value does not contradict the limit.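

In this assay compound 3 gives > 15000 nM, which is a limit of the assay and not a number. Compound 1 also stands at a limit, so no step can be read between compound 1 and compound 3. The compounds shown leave open what exact value any of them has and whether this single change alters it, because all sit at one level: the limit of > 15000 nM in this assay, at which 3 of the 3 values shown sit.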